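The source may hold more compounds than are shown below. What is called first, only, known or untested is meant among the compounds shown, and "the series" means these compounds.

Compound 1 `NS(=O)(=O)c1ccc(-c2oc3ccccc3c(=O)c2-c2ccc(F)cc2)cc1` carries an unsubstituted sulfonamide and inhibits strongly: in an assay on isolated protein for inhibition of prostaglandin G/H synthase 1 (Mus musculus), tested at 10 ug/mL (a lower number here means less inhibition, a higher number more inhibition at the concentration tested (going by the name of the read-out)), compound 1 gives 67%. Compound 2 `CS(=O)(=O)c1ccc(-c2oc3ccccc3c(=O)c2-c2ccc(F)cc2)cc1` differs only in having a methyl on the sulfonyl sulfur in place of the amino group. In this assay compound 2 shows < 8%, which is a limit of the assay and not a number. Among the measured compounds shown here, that single change, a number at least 59 percentage points lower from compound 1 to compound 2 (beyond the scatter), is the only measured step here. Compound 3 `CS(=O)(=O)c1ccc(-c2oc3ccccc3c(=S)c2-c2ccc(Cl)c(Cl)c2)cc1` also bears the methylsulfonyl group, together with a thiocarbonyl and a dichlorophenyl. In this assay compound 3 shows < 5%, again a limit rather than a number.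

Compound 4 `COc1ccc(-c2c(-c3ccc(S(C)(=O)=O)cc3)oc3ccccc3c2=O)cc1` keeps everything of compound 2 and changes one group: methoxy in place of fluoro on an aromatic carbon. For the measured compounds named here, no measured step touches this group, so the only guide is where compound 2 stands, at a limit, and the fact that the methylsulfonyl compounds 2 and 3 both sit at limits. Compound 4 is therefore expected to give 8%, in a range from 0% to 25%. The expected step of a number no lower from compound 2 to compound 4 (the limit leaves the size open) is small, within the scatter, and quite possibly compound 4 will also be reported only as a limit.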

Compound 4, a percentage reported as inhibition, at one concentration (the size of the read-out at that concentration, not a potency): < 5%
Compound 4: only a limit was reported; the forecaster's own chance of this, stated with the estimate: 60%; middle value at least 3 percentage points from the limit.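

Compound 2 and compound 4 are both reported only as limits in this assay, and the step between them cannot be read. The compounds shown leave open whether 4-methoxyphenyl in place of 4-fluorophenyl changes inhibition at all, and what actual readings compound 2, compound 3 and compound 4 would give.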